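A few compounds are considered here, and "the series" means these few. Any claim that something is new, unique, unknown or untested is made for them only; others in the source may bear on it.

Compound 1 `COc1ccc(NC(=O)Nc2nnc(Sc3ncnc4scc(-c5ccncc5)c34)s2)cc1` gives in a functional assay on T47D cells (Homo sapiens) for antiproliferative activity, read by MTT assay, with a stated time of 48 h (a lower number here means a stronger inhibitor, a higher number a weaker inhibitor), only a limit, > 100000 nM. Within the data shown here, compound 2 `O=C(Nc1ccc(Cl)cc1)Nc1nnc(Sc2ncnc3scc(-c4ccncc4)c23)s1` gives in this assay the single number of the series, 23300 nM. Among the measured compounds shown here, the one measured step is an at least 4.2-fold lower number from compound 1 to compound 2 (0.63 log units; beyond the scatter), its size bounded by the limit of > 100000 nM in this assay, at which 1 of the 2 values shown sits. Compound 3 `O=C(Nc1cccc(F)c1)Nc1nnc(Sc2ncnc3scc(-c4ccncc4)c23)s1` carries 3-fluorophenyl in place of 4-chlorophenyl on an amide-type nitrogen. For the measured compounds named here, no measured step touches this position or this halogen; the only evidence is that a para substituent swap moved the number beyond the scatter. A step of a 1.7-fold higher number from compound 2 to compound 3 (0.23 log units; within the scatter) is expected, toward a weaker number. Compound 3 is estimated at 40000 nM, within 15000 nM to 150000 nM.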

Compound 3, half-maximal inhibitory concentration: 16700 nM
Compound 3: middle estimate off by 2.4-fold (0.38 log units), on the high side; the range from low to high includes it.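

In this assay, replacing 4-chlorophenyl with 3-fluorophenyl on the amide-type nitrogen gives a 1.4-fold lower number from compound 2 to compound 3 (0.14 log units; within the scatter), so this change separates compound 2 and compound 3 by no more than the usual scatter. Replacing 4-methoxyphenyl with 3-fluorophenyl gives an at least 5.9-fold lower number from compound 1 to compound 3 (0.77 log units; beyond the scatter), so a second halogen-bearing phenyl group stands clear of the methoxy compound. Compound 1 is only a limit, which bounds that step: the limit of > 100000 nM in this assay, at which 1 of the 3 values shown sits.

The halogen and its place on the ring change together here, and their contributions cannot be separated. As far as these compounds go, how an amine or a carboxylic acid on this phenyl ring would read remains open.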